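Trading an Amide for an Aryl Ester

The compounds below may be only part of what the source reports. "The series", "measured", "known", "first", "only" and "open" are said of these compounds alone.

Compound 1, `CCOC(=O)CN(C)C(=O)c1ccc(C(CC)(CC)c2ccc(OCC(O)C(C)(C)C)c(C)c2)n1CC`, was tested in a functional assay on MCF7 cells (Homo sapiens), read by MTT assay, with a stated time of 48 h (on this read-out higher numbers stand for weaker inhibition and lower numbers for stronger inhibition), where compound 1 gives 9200 nM. For the measured compounds named here, that is the only plain number in this small set, so compound 1 stands as the lone measured value; the other entry is a limit. Compound 2, `C#CC(C)OC(=O)c1ccc(C(CC)(CC)c2ccc(OCC(O)C(C)(C)C)c(C)c2)n1CC`, reaches only a limit of the assay in this assay, reported as > 50000 nM. For compound 2 that is the limit of > 50000 nM in this assay, at which 1 of the 2 values shown sits. Going by the values given here, the step of an at least 5.4-fold higher number from compound 1 to compound 2 (0.73 log units; beyond the scatter) is the single measured comparison, and it shows that replacing the amide on a carbonyl carbon with an ester weakened inhibition at least modestly.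

Compound 3, `CCn1c(C(=O)Oc2ccc(CCO)cc2)ccc1C(CC)(CC)c1ccc(OCC(O)C(C)(C)C)c(C)c1`, has not yet been measured. It differs from compound 1 by a group of 10 heavy atoms (8 carbon, 2 oxygen; one six-membered aromatic ring of carbon only) in place of a group of 8 heavy atoms (5 carbon, 1 nitrogen, 2 oxygen; no ring), on a carbonyl carbon. Like compound 2, compound 3 carries an ester rather than the amide on that carbonyl carbon, so the one relevant step, the weakening from compound 1 to compound 2, points toward weaker inhibition here too. The step from compound 1 to compound 3 is therefore estimated as a 3.3-fold higher number from compound 1 to compound 3 (0.51 log units; beyond the scatter). Compound 3 is expected to give about 30000 nM, within a range from 8000 nM to 120000 nM, with a fair chance that only a limit is reported.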

Compound 3, half-maximal inhibitory concentration: > 50000 nM
Compound 3 gave a limit, no number (the forecaster's own chance of this, stated with the estimate: 40%); middle value at least 1.6-fold (0.22 log units) from the limit.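

Replacing ((ethoxycarbonyl)methyl)(methyl)amino on a carbonyl carbon with the 4-(2-hydroxyethyl)phenyl ester gives an at least 5.4-fold higher number from compound 1 to compound 3 (0.73 log units; beyond the scatter), so the weakening seen with an ester at this position no longer rests on compound 2 alone. The two esters are quite different, since compound 2 carries 1-methylprop-2-yn-1-yl with no ring and compound 3 carries an aromatic ring, yet both fall well short of the amide compound 1 in this assay. The step between compound 2 and compound 3 cannot be read, so the data do not rank these two esters, and compound 1 remains the only compound with a plain number: the limit of > 50000 nM in this assay, at which 2 of the 3 values shown sit.

The compounds shown leave open whether the loss follows from the ester link itself or from the particular groups attached to it, and how far the true values of the two esters lie from that of compound 1. The free carboxylic acid, a simple methyl ester, or an amide carrying a 4-(2-hydroxyethyl)phenyl group on the same carbonyl carbon would help separate these possibilities.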